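Compound 3 and the Step from Phenoxy to Hydroxy

The compounds below may be only part of what the source reports. "The series", "measured", "known", "first", "only" and "open" are said of these compounds alone.

Among the measured compounds shown here, in a functional assay on HT-29 cells (Homo sapiens) for inhibition, read by sulforhodamine B assay, with a stated time of 72 h (a lower number here means a stronger inhibitor, a higher number a weaker inhibitor), compound 3 (`COc1cc(N2C(=O)C(Oc3ccccc3)C2c2ccc(SC)cc2)cc(OC)c1OC`) gives 336 nM, the second highest of the three numbers so far. That value lies within the scatter of compound 1 (`COc1ccc(C2C(O)C(=O)N2c2cc(OC)c(OC)c(OC)c2)cc1O`), which gives 463 nM. Compound 2 (`COc1ccc(C2C(Oc3ccccc3)C(=O)N2c2cc(OC)c(OC)c(OC)c2)cc1`) gives 52 nM, clearly the lowest number. For the measured compounds named here, the one measured step, a 6.5-fold higher number from compound 2 to compound 3 (0.81 log units; beyond the scatter), is methylsulfanyl in place of methoxy on an aromatic carbon, and it does not touch the group that changes next.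

Compound 4 (`COc1cc(N2C(=O)C(O)C2c2ccc(SC)cc2)cc(OC)c1OC`) keeps the methylsulfanyl group of compound 3 and differs as follows: hydrogen in place of phenyl on an oxygen on a saturated carbon. This is hydrogen in place of phenyl on an oxygen on a saturated carbon, or phenoxy to hydroxy. Going by the values given here, no measured step isolates that change. Among the compounds with values here, the only measured hydroxy compound, compound 1 at 463 nM, differs from compound 2 in more than one place, so it is only a loose guide. A small rise in this assay, possibly within the scatter, is therefore expected: a 1.8-fold higher number from compound 3 to compound 4 (0.25 log units; within the scatter). For compound 4 the estimated value is 600 nM, with an expected range of 130 nM to 2800 nM.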

Compound 4, half-maximal inhibitory concentration: 15 nM
Beside the measured number, compound 4's estimate is 40-fold (1.60 log units) above it; the whole stated range lies above it.
By their numbers in this assay, from the lowest: compound 4; then compound 2; then compounds 3 and 1 (each within the scatter of the next).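

In this assay, among the compounds shown here, with the methylsulfanyl group held in place, hydrogen in place of phenyl on the oxygen gives a 22-fold lower number from compound 3 to compound 4 (1.35 log units; beyond the scatter), the first reading that isolates this position. For the compounds shown here, the hydroxy group here therefore goes with a far lower number than phenoxy, a change the earlier compounds could not separate from other differences. With the hydroxy group kept, the group on the saturated ring carbon also matters: 4-(methylsulfanyl)phenyl in place of 3-hydroxy-4-methoxyphenyl gives a 31-fold lower number from compound 1 to compound 4 (1.49 log units; beyond the scatter), so this substituent can move the number a long way.

Going by these compounds, it remains open whether an amine or a methoxy group on that saturated carbon would keep a number this low, or whether the step from phenoxy to hydroxy would be as large with another aryl group on the ring. The data shown offer no evidence on why this step is so large.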